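Ring Expansion of the Basic Amine in a Sulfonyl Series

The source may report more compounds than this note shows. Statements on the series, on what has been measured and on what is new or still open speak of the compounds shown alone.

Measured compounds:
compound 1, `CN1CCN(CCCS(=O)(=O)c2ccc3nc(NC(=O)NC(=O)c4ccccc4Cl)sc3c2)CC1`, 1.8;
compound 2, `CCOc1ccc(Cl)c(C(=O)NC(=O)Nc2nc3ccc(S(=O)(=O)CCCN4CCN(C)CC4)cc3s2)c1`, 2.4;
compound 3, `Cc1ccn(-c2ccc(Cl)c(C(=O)NC(=O)Nc3nc4ccc(S(=O)(=O)CCCN5CCN(C)CC5)cc4s3)c2)n1`, 2.6.

In a physicochemical assay for lipophilicity (a higher number here means a more lipophilic compound, a lower number a more polar compound), compound 1 stands lowest of the three, with a number 0.60 log units higher from compound 1 to compound 2 (beyond the scatter) and a number 0.80 log units higher from compound 1 to compound 3 (beyond the scatter), while a number 0.20 log units higher from compound 2 to compound 3 (within the scatter). Compound 4, `CN1CCCN(CCCS(=O)(=O)c2ccc3nc(NC(=O)NC(=O)c4ccccc4Cl)sc3c2)CC1`, is not yet measured. It differs from compound 1 in one place: 4-methyl-1,4-diazepan-1-yl in place of 4-methylpiperazin-1-yl on a saturated chain carbon, three bonds along the chain from a sulfonyl sulfur. Within the data shown here, none of the measured steps touches this end of the molecule; all three concern the aromatic carbon, so no step in this assay bears directly on the change. The seven-membered ring replacing the six-membered one is expected to give at most a small rise, a number 0.30 log units higher from compound 1 to compound 4 (within the scatter), likely within the scatter. Compound 4 is therefore estimated at 2.1, between 1.7 and 2.5.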

Compound 4, distribution coefficient: 1
The estimate for compound 4 lay 1.10 log units above the measured number; measured number outside the range, below it.
By their numbers in this assay, from the lowest: compound 4; then compound 1; then compounds 2 and 3 (each within the scatter of the next).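

In this assay the change at this end of the molecule moves the number downward, with a number 0.80 log units lower from compound 1 to compound 4 (beyond the scatter) even though 4-methyl-1,4-diazepan-1-yl carries one more carbon than 4-methylpiperazin-1-yl. Among these compounds, the earlier steps all lay on the aromatic carbon, so this is the first reading showing that the saturated chain end also matters in this assay. Nothing measured here accounts for the drop.

Going by these compounds, it remains open whether the same ring change would give a similar drop alongside the ethoxy or 3-methyl-1H-pyrazol-1-yl groups of compound 2 and compound 3. Also open, on these data alone, is how an open-chain dimethylamino group or a longer chain would behave at this position.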